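The compounds below may be only part of what the source reports. "The series", "measured", "known", "first", "only" and "open" are said of these compounds alone.

Measured compounds in an assay on CHO cells for binding affinity to D(4) dopamine receptor (Homo sapiens); on this read-out higher numbers stand for weaker inhibition and lower numbers for stronger inhibition: compound 1 `OCc1ccc(N2CCN(CC[C@H](O)c3ccc(Cl)cc3)CC2)cc1Cl` gives 8.6 nM; compound 2 `Cc1ccc(N2CCN(CCC3NC(=O)c4ccccc43)CC2)cc1` gives 12.4 nM; compound 3 `O=C1NC(CCN2CCN(c3ccccc3)CC2)c2ccccc21` gives 24.5 nM.

Compound 3 has the highest number of the three. Its nearest neighbour is compound 2, and the step from compound 2 to compound 3 in this assay was a 2.0-fold higher number from compound 2 to compound 3 (0.30 log units; within the scatter), a hydrogen in place of a methyl on the aryl ring of the piperazine. Compound 1, with a different core, sits furthest away, and its value against that of compound 3 lies beyond the scatter.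

Compound 4 `COc1ccc(N2CCN(CCC3NC(=O)c4ccccc43)CC2)cc1` is the next variation of the same core. The change from compound 3 to compound 4 is methoxy in place of hydrogen on an aromatic carbon. Within the data shown here, the only step that bears on it is the methyl-to-hydrogen step from compound 2 to compound 3, which was within the scatter. A methoxy at the same place is expected to behave much like that methyl, so the expected step of a 1.6-fold lower number from compound 3 to compound 4 (0.21 log units; within the scatter) in this assay is small, if anything towards a lower number, and not clearly beyond the scatter. Compound 4 is therefore expected at about 15 nM, with a range from 6 nM to 38 nM.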

Compound 4, inhibition constant: 37.3 nM
Compound 4: middle estimate off by 2.5-fold (0.40 log units), on the low side; measured number inside the range.
By their numbers in this assay, from the lowest: compounds 1, 2, 3 and 4 (each within the scatter of the next, the first and the last beyond it).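

In this assay, methoxy on the aromatic carbon para to a large group cannot be told apart from hydrogen (a 1.5-fold higher number from compound 3 to compound 4 (0.18 log units; within the scatter)), yet it does separate from methyl at the same place (a 3.0-fold higher number from compound 2 to compound 4 (0.48 log units; beyond the scatter)). The earlier methyl-to-hydrogen step lay within the scatter, so this third group gives the first difference beyond the scatter at this position, and that difference is between methyl and methoxy only. Nothing available gives a reason for that gap.

Open, on these data alone, is how an amine, a carboxylic acid or a chlorine at this place would read against these three groups in this assay. Also open, as far as these compounds go, is whether methoxy on another carbon of the same ring would read as it does here.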